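Ring-amine methylation in the pyridyl series

The compounds below may be only part of what the source reports. "The series", "measured", "known", "first", "only" and "open" are said of these compounds alone.

Measured compounds, with values in an in vitro assay on SH-EP1 cells for displacement of a labelled ligand from Neuronal acetylcholine receptor; alpha4/beta2 (Homo sapiens); a higher number here means a weaker inhibitor, a lower number a stronger inhibitor:
compound 1, `Clc1ccncc1C1=CC2CNCC(C1)C2`, gives 3 nM
compound 2, `CN1CC2C=C(c3cnccc3Cl)CC(C2)C1`, gives 1160 nM
compound 3, `C1=C(c2cccnc2)C[C@@H]2CNC[C@H]1C2`, gives 0.1 nM

Compound 3 has the lowest number of the three, and its distance from compound 1 and from compound 2 lies beyond the scatter. How the core of compound 3 differs from the core of compound 1 is not broken down here.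

For the measured compounds named here, the one step available in this assay is methyl in place of hydrogen on an amine nitrogen in a ring, which brought a 390-fold higher number from compound 1 to compound 2 (2.59 log units; beyond the scatter).

Compound 4, `CN1C[C@@H]2C=C(c3cccnc3)C[C@@H](C2)C1`, is not yet measured. It relates to compound 3 as compound 2 relates to compound 1: methyl in place of hydrogen on an amine nitrogen in a ring, the same kind of change at the same described place. Absent any other information, the expectation is that the step from compound 3 to compound 4 resembles the earlier one, estimated at a 300-fold higher number from compound 3 to compound 4 (2.48 log units; beyond the scatter). Going by the values given here, on that basis compound 4 is expected to give about 30 nM in this assay, with a plausible range from 4 nM to 250 nM, since only one prior example of the change is known and it rests on a different core.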

Compound 4, inhibition constant: 9.4 nM
Estimate against measurement, compound 4: 3.2-fold (0.50 log units) above; measured number inside the range.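

In this assay methyl in place of hydrogen on an amine nitrogen in a ring brought a 94-fold higher number from compound 3 to compound 4 (1.97 log units; beyond the scatter) on the core of compound 3, so the change raised the number on both cores shown. The direction of the change carried from one core to the other, but its size did not carry over unchanged: the same change on two cores in this assay, a 390-fold higher number (2.59 log units; beyond the scatter) from compound 1 to compound 2 and a 94-fold higher number (1.97 log units; beyond the scatter) from compound 3 to compound 4, 4.1-fold (0.61 log units) apart, beyond the scatter of two such steps

Two cores give no rule for a further core, and they do not say which feature of the cores sets the gap between the two steps.

The compounds shown leave open whether a larger group on the same ring nitrogen, such as ethyl, benzyl or a longer chain, would go the same way as methyl on either core. Also open, on these data alone, is whether an acetyl group in that place, which turns the amine into an amide, would keep the number low on the core of compound 3 or raise it as methyl does.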